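Furan-2-yl in Place of Phenyl: Estimating Compound 4

The source may hold more compounds than are shown below. What is called first, only, known or untested is meant among the compounds shown, and "the series" means these compounds.

Compound 1 `CC1=CC[C@H](C(C)(C)NC(=S)N/N=C/c2ccccc2)CC1` is the reference point of this account. In a functional assay on 786-0 cells (Homo sapiens) for inhibition, read by sulforhodamine B assay, with a stated time of 48 h (on this read-out higher numbers stand for weaker inhibition of growth and lower numbers for stronger inhibition of growth), compound 1 gives 9900 nM, which is the second highest of the three numbers recorded. Its nearest neighbour is compound 2 `COc1ccc(/C=N/NC(=S)NC(C)(C)[C@H]2CC=C(C)CC2)cc1`, which in this assay gives 8900 nM; the step is a 1.1-fold lower number from compound 1 to compound 2 (0.05 log units; within the scatter). Furthest away is compound 3 `CC1=CC[C@H](C(C)(C)NC(=S)N/N=C/c2ccccc2Cl)CC1`, which in this assay gives 85500 nM, a step of an 8.6-fold higher number from compound 1 to compound 3 (0.94 log units; beyond the scatter). Between these two there is a 9.6-fold higher number from compound 2 to compound 3 (0.98 log units; beyond the scatter).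

Compound 4 `CC1=CC[C@H](C(C)(C)NC(=S)N/N=C/c2ccco2)CC1` has not yet been measured. Its difference from compound 1 is furan-2-yl in place of phenyl on a carbon with a double bond to nitrogen. None of the three measured steps exchanges the aromatic ring itself: two of them add a single group to the phenyl of compound 1, and the third swaps one substituted phenyl for another. For the measured compounds named here, the only step that left the ring unchanged apart from one added group, a 1.1-fold lower number from compound 1 to compound 2 (0.05 log units; within the scatter), stayed within the scatter, whereas the chloro-bearing compound 3 moved beyond it. Going by the values given here, with no measured step matching the ring exchange, the author expects a 1.2-fold higher number from compound 1 to compound 4 (0.08 log units; within the scatter), that is, no step beyond the scatter, with the range widened for the unknown ring. Compound 4 is therefore estimated at 12000 nM, between 4000 nM and 40000 nM.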

Compound 4, concentration for 50% growth inhibition: 11700 nM
Beside the measured number, compound 4's estimate is 1.0-fold (0.01 log units) above it; the measured number falls inside the stated range.
By their numbers in this assay, from the lowest: compounds 2, 1 and 4 (each within the scatter of the next); then compound 3.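

Exchanging the aromatic ring itself, rather than adding a group to it, gives in this assay a 1.2-fold higher number from compound 1 to compound 4 (0.07 log units; within the scatter) and so shows that, on this carbon with a double bond to nitrogen, phenyl can give way to a five-membered aromatic ring with 1 hetero atom without a step beyond the scatter. Furan-2-yl also stays within the scatter of the 4-methoxyphenyl group, with a 1.3-fold higher number from compound 2 to compound 4 (0.12 log units; within the scatter) in the same read-out, so compounds 1, 2 and 4 now form a group of three that cannot be told apart in this assay. The remaining step, a 7.3-fold lower number from compound 3 to compound 4 (0.86 log units; beyond the scatter) and beyond the scatter, leaves the 2-chlorophenyl group of compound 3 as the only one of the four set apart from the others, and nothing at hand explains either that gap or the match between furan-2-yl and phenyl.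

Going by these compounds, whether a thiophen-2-yl or pyridin-3-yl ring on this carbon would also stay with compounds 1, 2 and 4 remains open. Also open, on these data alone, is whether a 4-chlorophenyl group would move the number as the 2-chlorophenyl group does.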